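Pyrrolidine substituent swap: phenyltriazole for methanesulfonamide

This account rests on a few compounds, and the source may have more. Where it says the series, first, only, none or still open, it means among the compounds named here.

Compound 1 `COc1ccc(-c2c(C)nc3c(N4CC[C@@H](NS(C)(=O)=O)C4)cc(C)nn23)cc1OC` carries a methanesulfonamido group on the pyrrolidine ring. In an ADME assay on microsomes from liver (Homo sapiens) for metabolic stability, read by LC-MS, with NADPH named in the record, with a stated time of 60 min, tested at 1 uM, in the absence of a further agent (on this read-out higher numbers stand for a more stable compound and lower numbers for a less stable compound), compound 1 gives > 95%, which is a limit of the assay and not a number. Compound 2 `COc1ccc(-c2c(C)nc3c(N4CC[C@@H](NS(=O)(=O)c5ccc(NC(C)=O)cc5)C4)cc(C)nn23)cc1OC` gives > 95% in this assay, again a limit. Compound 3 `COc1ccc(-c2c(C)nc3c(N4CC[C@H](O)C4)cc(C)nn23)cc1OC` gives > 95% in this assay, also a limit. The two measured steps, a step that the two limits leave unreadable from compound 1 to compound 2 and a step that the two limits leave unreadable from compound 1 to compound 3, therefore have no readable size, because of the limit of > 95% in this assay, at which 3 of the 3 values shown sit.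

Compound 4 `COc1ccc(-c2c(C)nc3c(N4CC[C@@H](n5cc(-c6ccccc6)nn5)C4)cc(C)nn23)cc1OC` differs from compound 1 by 4-phenyl-1H-1,2,3-triazol-1-yl in place of methanesulfonamido on a saturated ring carbon. Among the compounds with values here, no measured step bears on this change with a readable size; all that is known is that both a larger and a smaller substituent at this ring carbon have stayed at the limit. The expectation for compound 4 is a step of a number at least 13 percentage points lower from compound 1 to compound 4 (beyond the scatter), a modest loss that may not be seen beyond the scatter. The estimated value for compound 4 in this assay is 82%, within a range from 55% to 95%.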

Compound 4, percent of the compound remaining: "unstable" (no number reported)
For compound 4 the study gives words and no number, so the estimate cannot be set against anything.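

Within the data shown here, no step from compound 1 to compound 4 can be read in this assay, as compound 4 is reported only in words and compound 1 only as a limit. The compounds shown leave open what percentage of compound 4 remains, and which part of its 4-phenyl-1H-1,2,3-triazol-1-yl group decides that result.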